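The source may hold more compounds than are shown below. What is called first, only, known or untested is meant among the compounds shown, and "the series" means these compounds.

In a functional assay, with a stated time of 150 min, tested at 20 ug/mL (on this read-out higher numbers stand for a stronger effect at the one concentration tested and lower numbers for a weaker effect), compound 1 `Cc1ccc(C(=O)c2sc(Nc3ccccc3)c(C(=O)O)c2C)cc1` gives 2.68%, a weak effect at the one concentration tested. Its close relative compound 2 `Cc1ccc(Nc2sc(C(=O)c3ccc(C)cc3)c(C)c2C(=O)O)cc1` is reported in this assay as "not active" (no number reported), so no single number fixes where compound 2 stands; it appears to sit in the same weak region as compound 1. Compound 3 `Cc1ccc(C(=O)c2sc(Nc3ccc(F)cc3)c(C(=O)O)c2C)cc1` differs from compound 2 by fluoro in place of methyl on an aromatic carbon. Within the data shown here, with no measured pair of this kind to draw on, the change is expected to shift this assay by nothing beyond the usual scatter, in no clear direction. Compound 3 is therefore estimated to give 3% in this assay, with a range from 0% to 12%.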

Compound 3, a percentage reported as activity, at one concentration (the size of the read-out at that concentration, not a potency): "not active" (no number reported)
Compound 3 has no reported number here; no gap can be computed for the estimate.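

Compound 2 and compound 3 are both reported without a number in this assay, so no step can be read between them, and no supporting data bear on this result. From the compounds shown here alone, whether fluoro in place of methyl changes the effect at all remains open.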